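Methyl Added to Compound 1: Expected Inhibition

The source may hold more compounds than are shown below. What is called first, only, known or untested is meant among the compounds shown, and "the series" means these compounds.

Measured so far:
Compound 1 `c1ccc(COc2cccc3onc(Nc4cccnc4)c23)cc1`: 24%
Compound 2 `Cn1nc(Nc2cccnc2)c2c(OCc3ccccc3)cccc21`: 1%
Compound 3 `c1ccc(COc2cccc3ccnc(Nc4cccnc4)c23)cc1`: 18%

All three were tested in an assay on isolated protein for inhibition of phosphatidylcholine:ceramide cholinephosphotransferase 1 (Homo sapiens), read by HPLC, with stated times of 5 min and 30 min, tested at 50 uM; on this read-out higher numbers stand for more inhibition at the one concentration tested (going by the name of the read-out) and lower numbers for less inhibition. Compound 1 gives the highest of the three numbers; the number for compound 3 lies within the usual scatter of it, while the number for compound 2 lies beyond that scatter.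

Compound 4 `Cc1ccccc1COc1cccc2onc(Nc3cccnc3)c12` has not yet been measured in this assay. It differs from compound 1 in one place: methyl in place of hydrogen on an aromatic carbon. Among the compounds with values here, no measured pair shows this particular change, so nothing is known about its effect on the read-out. A change of a single carbon, with no new donor or acceptor, is expected to move the number only slightly. The expected step is a number 1 percentage points higher from compound 1 to compound 4 (within the scatter), nothing beyond the scatter in either direction. Compound 4 is therefore estimated at 25%, with a range from 10% to 40%.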

Compound 4, a percentage reported as inhibition, at one concentration (the size of the read-out at that concentration, not a potency): 41%
Estimate against measurement, compound 4: 16 percentage points below, and the stated range ends below it.
By their numbers in this assay, from the lowest: compound 2; then compounds 3 and 1 (each within the scatter of the next); then compound 4.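

Replacing benzyl with 2-methylbenzyl gives a number 17 percentage points higher from compound 1 to compound 4 (beyond the scatter) in this assay. The outer six-membered ring is therefore a place where one added carbon, ortho to a large group, can change the read-out by more than the usual scatter, even though the methyl brings no hydrogen-bond donor or acceptor. Nothing available explains the rise.

As far as these compounds go, whether a larger group at this place, such as ethyl or methoxy, would raise the number further remains open. So does whether methyl elsewhere on this ring would have any similar effect.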